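A 3-Aminophenyl Variant Measured Against a Weakly Cytotoxic Series

This account rests on a few compounds, and the source may have more. Where it says the series, first, only, none or still open, it means among the compounds named here.

Three compounds have so far been run in a functional assay on U2OS cells (Homo sapiens) for cytotoxicity, read by MTT assay, with a stated time of 48 h; on this read-out higher numbers stand for weaker inhibition and lower numbers for stronger inhibition:

Compound 1, `Fc1ccc2nc(-c3ccccc3)nc(Nc3ccccc3)c2c1`, for which this assay reports only a limit of > 50000 nM and no number.
Compound 2, `Fc1cccc(-c2nc(Nc3ccc(Cl)cc3)c3cc(F)ccc3n2)c1`, which in this assay gives 38400 nM.
Compound 3, `Oc1cccc(Nc2nc(-c3cccc(F)c3)nc3ccc(F)cc23)c1`, which in this assay gives 33300 nM.

Among the measured compounds shown here, compound 2 stands highest of the two actual numbers, with compound 3 nearest to it; the only single-point step available, a 1.2-fold lower number from compound 2 to compound 3 (0.06 log units; within the scatter), lies within the scatter, so no order between compound 2 and compound 3 can be read from these data. The remaining value is a limit (the limit of > 50000 nM in this assay, at which 1 of the 3 values shown sits).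

Compound 4, `Nc1cccc(Nc2nc(-c3cccc(F)c3)nc3ccc(F)cc23)c1`, has not yet been measured. It differs from compound 2 by 3-aminophenyl in place of 4-chlorophenyl on a nitrogen on an aromatic ring. For the measured compounds named here, the step from compound 2 to compound 3 is the one measured change at the same place on the same core, and it produced no movement beyond the scatter. With a group of the same kind entering at the same position, no step beyond the scatter is expected here either. Compound 4 is therefore estimated to give about 36000 nM in this assay, plausibly anywhere from 15000 nM to 85000 nM, which corresponds to an expected step of a 1.1-fold lower number from compound 2 to compound 4 (0.03 log units; within the scatter). Since this estimate sits close to the limit of this assay, there is a fair chance the result is reported as a limit rather than as a number.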

Compound 4, half-maximal inhibitory concentration: 49700 nM
Estimate against measurement, compound 4: 1.4-fold (0.14 log units) below; the range from low to high includes it.
By their numbers in this assay, from the lowest: compounds 3, 2 and 4 (each within the scatter of the next). At a limit, above all of these: compound 1.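

In this assay, the replacement of 4-chlorophenyl by 3-aminophenyl on the nitrogen gives a 1.3-fold higher number from compound 2 to compound 4 (0.11 log units; within the scatter), so a group counted with a hydrogen-bond donor and a hydrogen-bond acceptor, where 4-chlorophenyl has neither, leaves the number within the scatter. Among the compounds shown here, the exchange of hydroxy for amino on the same aromatic carbon, read directly for the first time, gives a 1.5-fold higher number from compound 3 to compound 4 (0.17 log units; within the scatter), so among compounds 2, 3 and 4 none of the three groups at this place separates from the others, and no compound among them goes against this. Compound 1 is held only as a limit, and with the other numbers lying this close to it, there is little room for any further rise to be read as a number: the limit of > 50000 nM in this assay, at which 1 of the 4 values shown sits.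

For the compounds shown here, compound 1 differs from the others in more than one place, so no step to it can be read. Whether a carboxylic acid, an amide or a longer chain on this aromatic ring would give a step beyond the scatter, and in which direction, remains open, since every group shown here leaves the number in the same narrow band.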